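Shifting Fluorines on the Benzoyl Ring of Compound 2

The source may report more compounds than this note shows. Statements on the series, on what has been measured and on what is new or still open speak of the compounds shown alone.

Within the data shown here, compound 2 `O=C(c1cccc(F)c1)N1CCCC[C@@H]1c1nc(-c2cccc(F)c2)no1` gives the lowest of the two numbers so far in an in vitro functional assay on HEK293-A cells for positive allosteric modulation of metabotropic glutamate receptor 5 (Homo sapiens), read by fluorescence and calcium flux, with a stated time of 140 s (on this read-out higher numbers stand for an effect only at larger amounts of compound and lower numbers for an effect already at smaller amounts), namely 460 nM. Compound 1 `O=C(c1ccc(F)c(F)c1)N1CCCC[C@@H]1c1nc(-c2cccc(F)c2)no1` gives 1400 nM in this assay, and the step of a 3.0-fold lower number from compound 1 to compound 2 (0.48 log units; beyond the scatter), which removed a fluoro from the benzoyl ring, brought the number down. Compound 3 `O=C(c1ccc(F)cc1F)N1CCCC[C@@H]1c1nc(-c2cccc(F)c2)no1` differs from compound 2 by 2,4-difluorophenyl in place of 3-fluorophenyl on a carbonyl carbon. Among the measured compounds shown here, no measured step tests this exact swap; the one related step, a 3.0-fold lower number from compound 1 to compound 2 (0.48 log units; beyond the scatter), shows the benzoyl ring with more fluorine giving the larger number. A modest rise beyond the scatter is therefore expected, a 2.0-fold higher number from compound 2 to compound 3 (0.29 log units; within the scatter). Compound 3 is estimated at 900 nM, within a range from 300 nM to 2700 nM.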

Compound 3, half-maximal effective concentration: 2900 nM
Beside the measured number, compound 3's estimate is 3.2-fold (0.51 log units) below it; measured number above the stated range.
By their numbers in this assay, from the lowest: compound 2; then compound 1; then compound 3.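

With the same number of fluorines on the benzoyl ring, rearranging them alone gives a 2.1-fold higher number from compound 1 to compound 3 (0.32 log units; beyond the scatter), so at this position where the fluorines sit matters, not only how many there are. Replacing 3-fluorophenyl with 2,4-difluorophenyl gives a 6.3-fold higher number from compound 2 to compound 3 (0.80 log units; beyond the scatter), leaving the new arrangement with the highest number of the three. Nothing available explains why the arrangement changes the number.

Still open, from the compounds shown here alone, is whether a benzoyl ring with no fluoro at all, or one carrying a methoxy group or a nitrile, would give a number lower than that of compound 2.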